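The compounds below may be only part of what the source reports. "The series", "measured", "known", "first", "only" and "open" are said of these compounds alone.

Compound 1, `CCN(CC)CN1C(=O)/C(=N/NC(N)=S)c2cc(Cl)ccc21` — in an ADME assay on HeLa cells (Homo sapiens) for cytotoxicity (a higher number here means that more compound is tolerated, a lower number that less compound is tolerated), compound 1 gives > 100000 nM, a limit of the assay.
Compound 2, `CCN(CC)CN1C(=O)/C(=N/NC(N)=S)c2ccccc21` — compound 2 gives > 100000 nM, again a limit.
Compound 3, `CCN(CC)CN1C(=O)/C(=N/NC(=S)Nc2ccccc2)c2ccccc21` — compound 3 gives >= 20000 nM, also a limit.

Compound 1 therefore stands only at a limit, as do the two other measured compounds. Compound 4, `CCN(CC)CN1C(=O)/C(=N/NC(=S)Nc2ccc(OC)cc2)c2cc(Cl)ccc21`, differs from compound 1 by 4-methoxyphenyl in place of hydrogen on an amide-type nitrogen. Within the data shown here, the steps that bear on this change are a step that the two limits leave unreadable from compound 1 to compound 2 and a step that the two limits leave unreadable from compound 2 to compound 3; neither gives a readable size, since the limit of > 100000 nM in this assay, at which 2 of the 3 values shown sit, and the limit of >= 20000 nM in this assay, at which 1 of the 3 values shown sits, bound them on both sides. For this assay she therefore expects no step beyond the scatter, the change for compound 4 estimated as a number no higher from compound 1 to compound 4 (the limit leaves the size open). Her estimate for compound 4 is 100000 nM, within 20000 nM to 300000 nM.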

Compound 4, minimum cytotoxic concentration: 4000 nM
Beside the measured number, compound 4's estimate is 25-fold (1.40 log units) above it; measured number below the stated range.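

In this assay, among these compounds, 4-methoxyphenyl in place of hydrogen on the amide-type nitrogen brings an at least 25-fold lower number from compound 1 to compound 4 (1.39 log units; beyond the scatter), the first readable step. Among the compounds shown here, it shows that this position can move the number beyond the scatter, which the earlier steps could not show, as none of them can be read. The new step remains open at one end because compound 1 stands at a limit: the limit of > 100000 nM in this assay, at which 2 of the 4 values shown sit.

The compounds shown leave open whether the step belongs to the methoxy group or to the aromatic ring that carries it. They also leave open what an ethyl chain or a carboxylic acid would do at this nitrogen.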